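Working notes: compound 4 expected from compound 2

The source may hold more compounds than are shown below. What is called first, only, known or untested is meant among the compounds shown, and "the series" means these compounds.

Measured so far in a functional assay on U-87MG ATCC cells for antiproliferative activity against U-87 MG (Homo sapiens), read by MTT assay, with a stated time of 48 h, tested at 50 uM; a lower number here means a stronger effect, a higher number a weaker effect of the compound at the concentration tested:
- compound 1 `COc1ccc(-c2nc(C)c(C(=O)CSc3nc(N)c(C#N)c(-c4ccc(Cl)cc4)n3)s2)cc1`: 23.1%
- compound 2 `Cc1nc(-c2ccc(Cl)cc2)sc1C(=O)CSc1nc(-c2ccccc2)c(C#N)c(=O)[nH]1`: 41.6%
- compound 3 `Cc1nc(-c2ccccc2)sc1C(=O)CSc1nc(-c2ccccc2)c(C#N)c(=O)[nH]1`: 77.5%

Compound 2 holds the second highest of the three numbers; compound 1 lies lower by a margin beyond the scatter, compound 3 lies higher by a margin beyond the scatter. Compound 1 and compound 2 differ in several places at once, so their two values are taken only as they stand.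

For the measured compounds named here, the single measured step, a number 35.9 percentage points higher from compound 2 to compound 3 (beyond the scatter), concerns hydrogen in place of chloro on an aromatic carbon; it does not touch the phenyl that is exchanged in compound 4.

Compound 4 `COc1ccc(-c2nc(SCC(=O)c3sc(-c4ccc(Cl)cc4)nc3C)[nH]c(=O)c2C#N)cc1OC` arises from compound 2 by 3,4-dimethoxyphenyl in place of phenyl on an aromatic carbon. Going by the values given here, no measured step covers an exchange of this kind, so no direction can be read from the series; the expectation is a step of no size beyond the scatter, with wide uncertainty. Compound 4 is therefore estimated at 42%, within 22% to 65%, which is the expected step of a number 0.4 percentage points higher from compound 2 to compound 4 (within the scatter).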

Compound 4, a percentage reported as activity, at one concentration (the size of the read-out at that concentration, not a potency): 59.8%
Compound 4: middle estimate off by 17.8 percentage points, on the low side; the measured number falls inside the stated range.
By their numbers in this assay, from the lowest: compound 1; then compound 2; then compound 4; then compound 3.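

In this assay, the aryl group ortho to a cyano group and next to the ring nitrogen proves sensitive to exchange: 3,4-dimethoxyphenyl in place of phenyl gives a number 18.2 percentage points higher from compound 2 to compound 4 (beyond the scatter) and so a weaker effect at the concentration tested. For the compounds shown here, the earlier step, a number 35.9 percentage points higher from compound 2 to compound 3 (beyond the scatter), concerned only the chloro on the other aryl ring, so this is the first reading at this position, and here too the exchange away from compound 2 raises the number. No measured property of these compounds accounts for the step.

A single methoxy, as in 3-methoxyphenyl or 4-methoxyphenyl, would show whether one group carries the step or both are needed. On these data alone, whether a 4-chlorophenyl or a pyridyl at this position would lower the number also stays open.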